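The compounds below may be only part of what the source reports. "The series", "measured", "known", "first", "only" and "open" are said of these compounds alone.

Measured in a functional assay on Jurkat E6.1 cells (Homo sapiens) for cytotoxicity, read by MTT assay, with a stated time of 24 h; on this read-out higher numbers stand for weaker inhibition and lower numbers for stronger inhibition:
compound 1 `COC(=O)/C(=C\c1ccc(OC(=O)c2ccccc2)cc1)Sc1ccnc2cc(Cl)ccc12` gives 35700 nM
compound 2 `COC(=O)/C(=C\c1ccc(OC(=O)c2cccc(OC)c2OC)cc1)Sc1ccnc2cc(Cl)ccc12` gives 25800 nM

Of the two numbers, that of compound 2 is the lower, but the gap, a 1.4-fold lower number from compound 1 to compound 2 (0.14 log units; within the scatter), lies within the scatter and separates nothing. Compound 3 `COC(=O)/C(=C\c1ccc(OC(=O)c2cc(OC)c(OC)c(OC)c2)cc1)Sc1ccnc2cc(Cl)ccc12` carries 3,4,5-trimethoxyphenyl in place of 2,3-dimethoxyphenyl on a carbonyl carbon. Within the data shown here, the only measured step bearing on the aryl group at this carbonyl carbon, a 1.4-fold lower number from compound 1 to compound 2 (0.14 log units; within the scatter), stayed within the scatter, so a further change of that aryl group is expected to give no step beyond the scatter in this assay. Compound 3 is expected at 23000 nM (range 9000 nM to 60000 nM), an expected step of a 1.1-fold lower number from compound 2 to compound 3 (0.05 log units; within the scatter).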

Compound 3, half-maximal inhibitory concentration: 4570 nM
Compound 3: middle estimate off by 5.0-fold (0.70 log units), on the high side; measured number outside the range, below it.
By their numbers in this assay, from the lowest: compound 3; then compounds 2 and 1 (each within the scatter of the next).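

In this assay the aryl group on this carbonyl carbon can move the number: 3,4,5-trimethoxyphenyl in place of 2,3-dimethoxyphenyl gives a 5.6-fold lower number from compound 2 to compound 3 (0.75 log units; beyond the scatter) and lies beyond the scatter. Against phenyl the same group gives a 7.8-fold lower number from compound 1 to compound 3 (0.89 log units; beyond the scatter) and this shows that carrying methoxy groups alone does not set the number, since compound 2 also carries them yet stays within the scatter of compound 1. Nothing measured on these compounds accounts for the step.

Going by these compounds, whether the third methoxy group or the placement of the methoxy groups matters stays open: compound 2 and compound 3 differ in both. Also open, on these data alone, is how a hydroxy group or an amine on that aryl ring would compare.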